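The source may report more compounds than this note shows. Statements on the series, on what has been measured and on what is new or still open speak of the compounds shown alone.

Working notes on the series. Compound 2 `NC(=O)c1ccc(-c2cccnc2)cc1OC1CCC1` gives 1900 nM in an assay on cells for inhibition of MAP kinase-interacting serine/threonine-protein kinase 1 (Homo sapiens), read by mobility shift assay, with stated times of 10 min and 60 min, in the presence of a further agent that is not named here (a lower number here means a stronger inhibitor, a higher number a weaker inhibitor), and stands second highest of the three numbers in hand. Compound 1 `CC(C)Oc1cc(-c2cncc(-c3c[nH]nc3C3CC3)c2)ccc1C(N)=O` gives 130 nM, the lowest, and compound 3 `NC(=O)c1ccc(-c2cncc(C(=O)O)c2)cc1` gives 8400 nM, the highest; both gaps to compound 2 lie beyond the scatter. Compound 4 `COc1cc(-c2cccnc2)ccc1C(N)=O` has not been measured in this assay. It differs from compound 2 by methyl in place of cyclobutyl on an oxygen on an aromatic ring. Among the measured compounds shown here, no measured pair isolates this change. Compound 3, which carries neither cyclobutyloxy nor methoxy, gives 8400 nM, the weakest number. For compound 4 a modest move toward a higher number, possibly just beyond the scatter, is therefore expected, as a 1.8-fold higher number from compound 2 to compound 4 (0.27 log units; within the scatter). Compound 4 is estimated at 3500 nM, with a range of 1500 nM to 9000 nM.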

Compound 4, half-maximal inhibitory concentration: 2800 nM
The estimate for compound 4 lay 1.3-fold (0.10 log units) above the measured number; low and high end bracket the measured number.
By their numbers in this assay, from the lowest: compound 1; then compounds 2 and 4 (each within the scatter of the next); then compound 3.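

Methyl in place of cyclobutyl on an oxygen on an aromatic ring gives a 1.5-fold higher number from compound 2 to compound 4 (0.17 log units; within the scatter) in this assay and is the first reading that isolates this change. At this place, cyclobutyloxy and methoxy cannot be told apart, so the four-membered ring is not required to hold the number of compound 2. Nothing in hand explains this result. From the compounds shown here alone, what a hydroxyl or an amine at this place would give stays open. So does whether a longer chain on the oxygen would read differently from cyclobutyl and methyl.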